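The compounds below may be only part of what the source reports. "The series", "measured", "known", "first", "only" and "open" are said of these compounds alone.

Values in a functional assay on PC-3 cells (Homo sapiens) for antiproliferative activity, read by WST assay, with a stated time of 3 days; on this read-out higher numbers stand for weaker inhibition and lower numbers for stronger inhibition:
- compound 1 `CCCCOc1c(-c2cc(OC)c(OC)c(OC)c2)oc2ccccc2c1=O`: 12800 nM
- compound 2 `CCCCCCCOc1c(-c2cc(OC)c(OC)c(OC)c2)oc2ccccc2c1=O`: > 50000 nM
- compound 3 `CCN(CC)CCCCOc1c(-c2cc(OC)c(OC)c(OC)c2)oc2ccccc2c1=O`: 13700 nM

Not yet measured: compound 4 `CCN(CC)CCCCCOc1c(-c2cc(OC)c(OC)c(OC)c2)oc2ccccc2c1=O`.

Compound 2 stands at > 50000 nM, which is a limit of the assay and not a number. Any step away from compound 2 is therefore known from one side only.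

The change to compound 4 is diethylamino in place of ethyl on a saturated chain carbon, five bonds along the chain from an oxygen on an aromatic ring. Cut one bond further out, the same difference reads pentyl to 3-(diethylamino)propyl.

The closest measured step is an at least 3.6-fold lower number from compound 2 to compound 3 (0.56 log units; beyond the scatter). It also brings in diethylamino, there four bonds along the chain from an oxygen on an aromatic ring. The other two steps set the context: a 1.1-fold higher number from compound 1 to compound 3 (0.03 log units; within the scatter) and an at least 3.9-fold higher number from compound 1 to compound 2 (0.59 log units; beyond the scatter). Within these three compounds, the diethylamino end group goes with a number rather than a limit, though the one-bond difference in place remains untested.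

A step of at least similar size, toward a lower number in this assay, is therefore expected. The step expected is an at least 4.1-fold lower number from compound 2 to compound 4 (0.61 log units; beyond the scatter).

For compound 4 the estimate is 12000 nM, with an expected range of 5000 nM to 30000 nM.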

Compound 4, half-maximal inhibitory concentration: 6600 nM
For compound 4 the middle estimate is 1.8-fold (0.26 log units) above the measured one, and the stated range covers the measured number.
By their numbers in this assay, from the lowest: compounds 4, 1 and 3 (each within the scatter of the next, the first and the last beyond it). At a limit, above all of these: compound 2.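

In this assay, moving diethylamino one bond further out, from four to five bonds along the chain from the oxygen on the aromatic ring, gives a 2.1-fold lower number from compound 3 to compound 4 (0.32 log units; beyond the scatter), so at this end group chain length alone moves the number by a modest amount. At the longer chain, the diethylamino end separates clearly from the plain alkyl chain, with an at least 7.5-fold lower number from compound 2 to compound 4 (0.87 log units; beyond the scatter), a step known from one side only, while the comparison with the shorter unsubstituted ether stays within the scatter, with a 1.9-fold lower number from compound 1 to compound 4 (0.29 log units; within the scatter). Compound 2 stands at a limit and not at a number, so the size of its step stays open: the limit of > 50000 nM in this assay, at which 1 of the 4 values shown sits.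

Among the compounds shown here, with only two chain lengths carrying diethylamino, a single step cannot show whether a longer chain with the same end group would continue in this direction or turn back. Whether the change depends on diethylamino itself also stays open, since the compounds shown hold no other end group, such as a primary amine, a piperidine, a morpholine or a carboxylic acid.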